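A Benzamide in Place of the Dichlorophenyl Amino Arm

A few compounds are considered here, and "the series" means these few. Any claim that something is new, unique, unknown or untested is made for them only; others in the source may bear on it.

In a functional assay on SF-295 cells (Homo sapiens) for inhibition, read by sulforhodamine B assay, with a stated time of 48 h (on this read-out lower numbers stand for higher toxicity in this test and higher numbers for lower toxicity in this test), compound 1 (`COc1cc(-c2nn(-c3cccc(NC(=O)Nc4ccc(Cl)c(Cl)c4)c3)cc2-c2ccncc2)ccc1Cl`) gives > 50000 nM, which is a limit of the assay and not a number. Among the measured compounds shown here, compound 2 (`O=C(Nc1cccc(-n2cc(-c3ccncc3)c(-c3ccc(Cl)c(O)c3)n2)c1)Nc1cc(C(F)(F)F)cc(C(F)(F)F)c1`) gives a true reading of 4390 nM, so only compound 2 offers a measured number so far. For the measured compounds named here, no measured step connects the two compounds, and neither reading says how a change at the carbonyl would play out.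

The next compound is compound 3 (`COc1cc(-c2nn(-c3cccc(NC(=O)c4ccccc4)c3)cc2-c2ccncc2)ccc1Cl`), which differs from compound 1 as follows: phenyl in place of (3,4-dichlorophenyl)amino on a carbonyl carbon. Apart from this change, the rest of the structure stays the same.

With compound 1 resting on (the limit of > 50000 nM in this assay, at which 1 of the 2 values shown sits), the step of a number no higher from compound 1 to compound 3 (the limit leaves the size open) is expected to stay within the usual scatter, with no direction favoured. The more likely outcome is that the new reading will again be only a limit of the assay. If a number is obtained, compound 3 is estimated at 50000 nM, with an expected range from 15000 nM to 100000 nM.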

Compound 3, concentration lethal to 50% of the cells: > 100000 nM
Compound 3 ended at the assay's limit (the forecaster's own chance of this, stated with the estimate: 70%); at least 2.0-fold (0.30 log units) between middle value and limit.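

In this assay, compound 3 gives > 100000 nM, which is a limit of the assay and not a number. Compound 1 also rests on a limit, > 50000 nM. Among the compounds shown here, no step can therefore be read between compound 1 and compound 3. The compounds shown leave open whether phenyl in place of (3,4-dichlorophenyl)amino on a carbonyl carbon changes the reading at all.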